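This account rests on a few compounds, and the source may have more. Where it says the series, first, only, none or still open, it means among the compounds named here.

Measured so far in a functional assay on MDA-MB-231 cells (Homo sapiens) for inhibition, read by CCK-8 assay, with a stated time of 48 h; on this read-out higher numbers stand for weaker inhibition of growth and lower numbers for stronger inhibition of growth:
Compound 1 `Cc1ccc(Nc2ncc(Cl)c(Nc3ccccc3C)n2)cc1` returns only a limit of the assay, > 100000 nM.
Compound 2 `Cc1ccccc1Nc1nc(Nc2ccc(N3CCN(C)CC3)cc2)ncc1Cl` gives 7020 nM.
Compound 3 `CN1CCN(c2ccc(Nc3ncc(Cl)c(NCc4ccccc4)n3)nc2)CC1` gives 24800 nM.

Among the two numbers known, compound 3 stands highest, and compound 2 sits below it. Going by the values given here, the only single-place step measured here is an at least 14-fold lower number from compound 1 to compound 2 (1.15 log units; beyond the scatter), a change in a different part of the molecule. Compound 4 `CCc1ccc(Nc2nc(Nc3ccc(N4CCN(C)CC4)cn3)ncc2Cl)cc1` is compound 3 with 4-ethylphenyl in place of benzyl on a nitrogen on an aromatic ring. Among the compounds with values here, no measured step covers this change, so the direction rests only on compound 2, whose aryl amine gives 7020 nM, a lower number than compound 3. A moderate step to a lower number is therefore expected, a 3.1-fold lower number from compound 3 to compound 4 (0.49 log units; beyond the scatter), with wide uncertainty. Compound 4 is estimated at 8000 nM, between 2500 nM and 25000 nM.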

Compound 4, concentration for 50% growth inhibition: 5560 nM
The estimate for compound 4 lay 1.4-fold (0.16 log units) above the measured number; low and high end bracket the measured number.
By their numbers in this assay, from the lowest: compounds 4 and 2 (each within the scatter of the next); then compound 3. At a limit, above all of these: compound 1.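

In this assay, placing 4-ethylphenyl instead of benzyl on this nitrogen gives a 4.5-fold lower number from compound 3 to compound 4 (0.65 log units; beyond the scatter). Going by these compounds alone, this is the first measured step at this position, and it shows that the group on this nitrogen can shift the growth-inhibition number, although the two groups differ by only one heavy atom. Nothing measured here explains why the number moves.

The change swaps benzylamino for (4-ethylphenyl)amino in a single step, so the part played by the ethyl group stays unseparated from that of the altered link to the ring. From the compounds shown here alone, how a plain phenyl, a 4-methoxyphenyl or a longer chain such as butyl would read on this nitrogen remains open.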